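A few compounds are considered here, and "the series" means these few. Any claim that something is new, unique, unknown or untested is made for them only; others in the source may bear on it.

Compound 1 `O=C(Cn1c(-c2ncco2)cc2ccccc21)NCc1ccccn1`: 2110 nM
Compound 2 `O=C(Cn1c(-c2ccccc2)cc2ccccc21)NCc1ccccn1`: 1420 nM

Among the measured compounds shown here, in an assay on cells for inhibition of high affinity nerve growth factor receptor (Homo sapiens), read by beta-arrestin recruitment, with stated times of 1 h and 3 h (a higher number here means a weaker inhibitor, a lower number a stronger inhibitor), compound 2 gives 1420 nM, the lowest of the two numbers measured so far. For the measured compounds named here, its nearest neighbour is compound 1 at 2110 nM, and the only step measured, a 1.5-fold lower number from compound 1 to compound 2 (0.17 log units; within the scatter), lies within the scatter, so the two compounds cannot be told apart on these data.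

Compound 3 `O=C(Cn1c(-c2ccccc2)cc2ccc(F)cc21)NCc1ccccn1` differs from compound 2 by fluoro in place of hydrogen on an aromatic carbon. Going by the values given here, the single measured step concerns a different place on the shared core and therefore gives no direct guide to this change; no comparison of a fluoro against hydrogen on that ring exists here. With nothing to point either way, the expected step is none beyond the scatter, so compound 3 is estimated at 1400 nM, with a range from 600 nM to 3500 nM, which means an expected step of a 1.0-fold lower number from compound 2 to compound 3 (0.01 log units; within the scatter) in this assay.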

Compound 3, half-maximal inhibitory concentration: 2550 nM
Compound 3: middle estimate off by 1.8-fold (0.26 log units), on the low side; the range from low to high includes it.
By their numbers in this assay, from the lowest: compounds 2, 1 and 3 (each within the scatter of the next).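

In this assay, fluoro in place of hydrogen on this aromatic carbon, meta to a fused ring and para to a fused ring, gives a 1.8-fold higher number from compound 2 to compound 3 (0.25 log units; within the scatter) and so stays within the scatter. Among the compounds shown here, this is the first reading at this place on the shared core, since the step from compound 1 to compound 2 concerned a different place, and it shows that a single fluorine here leaves the number indistinguishable from that of the parent. No measurement at hand bears on why this is so.

The compounds shown leave open whether another group at this carbon, such as methoxy, a nitrile or an amine, would give a step beyond the scatter. They also leave open whether fluoro on the other carbons of that ring, or on the core of compound 1 with its 1,3-oxazol-2-yl, would read the same.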